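Cytotoxicity limit and a swapped ring group

The source may report more compounds than this note shows. Statements on the series, on what has been measured and on what is new or still open speak of the compounds shown alone.

Measured in an ADME assay on Vero cells (Chlorocebus sabaeus) for cytotoxicity, with a stated time of 1 weeks; on this read-out lower numbers stand for higher toxicity in this test and higher numbers for lower toxicity in this test:
- compound 1 `O=c1ccn([C@H]2C[C@H](OC(c3ccccc3)(c3ccccc3)c3ccccc3)[C@@H](CO)O2)c(=O)[nH]1`: 4000 nM
- compound 2 `O=c1[nH]c(=O)n([C@@H]2O[C@H](COC(c3ccccc3)(c3ccccc3)c3ccccc3)[C@@H](O)[C@H]2OC(c2ccccc2)(c2ccccc2)c2ccccc2)cc1Cl`: > 70000 nM (a limit)

Compound 2 stands at the limit of > 70000 nM in this assay, at which 1 of the 2 values shown sits. Its value is a limit and not a number. For the measured compounds named here, compound 1 is the only compound here with a measured number, and no single-place step joins it to compound 2.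

Compound 3 `O=c1[nH]cnc2c1ncn2[C@@H]1O[C@H](COC(c2ccccc2)(c2ccccc2)c2ccccc2)[C@@H](O)[C@H]1OC(c1ccccc1)(c1ccccc1)c1ccccc1` differs from compound 2 in one place: a group of 10 heavy atoms (5 carbon, 4 nitrogen, 1 oxygen; one five-membered aromatic ring with 2 hetero atoms, one six-membered aromatic ring with 2 hetero atoms) in place of a group of 9 heavy atoms (4 carbon, 2 nitrogen, 2 oxygen, 1 chlorine; one six-membered aromatic ring with 2 hetero atoms), on a saturated ring carbon. The group of 10 heavy atoms, with one five-membered and one six-membered aromatic ring, takes the place of the group of 9 heavy atoms on a saturated ring carbon, next to the ring oxygen.

Going by the values given here, no measured step shows what this change does in this assay. The expectation therefore rests on compound 2 alone, with its limit of > 70000 nM. No shift beyond the usual scatter is expected, and no direction is favoured. The expected step is an at least 1.1-fold lower number from compound 2 to compound 3 (0.06 log units; that floor lies within the scatter). A report of compound 3 as a limit would not be surprising. The estimated value for compound 3 is 60000 nM, with an expected range from 15000 nM to 150000 nM.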

Compound 3, half-maximal cytotoxic concentration: 10000 nM
Compound 3: the middle estimate sits 6.0-fold (0.78 log units) above what was measured; measured number below the stated range.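

Working notes: at this place, on a saturated ring carbon of a five-membered non-aromatic ring with 1 oxygen, swapping the group of 9 heavy atoms for the group of 10 heavy atoms changes the read-out in this assay, giving an at least 7.0-fold lower number from compound 2 to compound 3 (0.84 log units; beyond the scatter). For the compounds shown here, this is the first single-place step, and it shows that the group at this place matters in this test with the rest of the structure held the same, the lower number standing for higher toxicity. The true size of the step stays open and only its floor can be read, because the starting point is a limit and not a number: the limit of > 70000 nM in this assay, at which 1 of the 3 values shown sits.

One swap cannot separate the parts of the change, so the added five-membered aromatic ring, the loss of the chlorine and the other differences between the two groups remain tied together. A small group such as an amine or a carboxylic acid on this ring carbon would show whether any aromatic ring system is needed here for the read-out to fall below the limit seen for compound 2.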